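Naphthoquinone sulfonylamidines: cytotoxicity outlook for benzyl analogue

The source may hold more compounds than are shown below. What is called first, only, known or untested is meant among the compounds shown, and "the series" means these compounds.

Measured compounds:
- Compound 1 `COc1ccc(N/C(CCNC2=CC(=O)c3ccccc3C2=O)=N\S(=O)(=O)c2ccc(C)cc2)cc1OC` gives 60600 nM in an ADME assay on HEK293 cells (Homo sapiens) for cytotoxicity, read by MTT assay, with a stated time of 48 h; on this read-out lower numbers stand for stronger inhibition and higher numbers for weaker inhibition.
- Compound 2 `Cc1ccc(S(=O)(=O)/N=C(/CCNC2=CC(=O)c3ccccc3C2=O)Nc2ccc(Cl)cc2Cl)cc1` gives 41900 nM in this assay.

Compound 2 stands at the low end of the two numbers recorded, yet the step of a 1.4-fold lower number from compound 1 to compound 2 (0.16 log units; within the scatter) is within the scatter, so compounds 1 and 2 cannot be told apart in this assay.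

Compound 3 `Cc1ccc(S(=O)(=O)/N=C(/CCNC2=CC(=O)c3ccccc3C2=O)NCc2ccccc2)cc1` has not yet been measured. It differs from compound 2 by benzyl in place of 2,4-dichlorophenyl on an amine nitrogen. Going by the values given here, the only measured step that bears on this position is the one from compound 1 to compound 2, which exchanged one aryl group for another on the same amine nitrogen and produced a 1.4-fold lower number from compound 1 to compound 2 (0.16 log units; within the scatter). Among the compounds with values here, no measured step replaces an aryl group by a benzyl group, so there is no direct precedent for this exchange. Given that the one change at this nitrogen moved the number so little, compound 3 is expected to stay close to compound 2, with a 1.2-fold higher number from compound 2 to compound 3 (0.08 log units; within the scatter) as the estimated step and no movement beyond the scatter. The estimate for compound 3 in this assay is 50000 nM, within a range of 20000 nM to 125000 nM.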

Compound 3, half-maximal inhibitory concentration: 80200 nM
For compound 3 the middle estimate is 1.6-fold (0.21 log units) below the measured one; the measured number falls inside the stated range.
By their numbers in this assay, from the lowest: compounds 2, 1 and 3 (each within the scatter of the next).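

Compound 3 adds a benzyl group to this amine nitrogen, where only directly comparable aryl exchanges had been read before, and in this assay the exchange for 2,4-dichlorophenyl gives a 1.9-fold higher number from compound 2 to compound 3 (0.28 log units; within the scatter), while the exchange for 3,4-dimethoxyphenyl gives a 1.3-fold higher number from compound 1 to compound 3 (0.12 log units; within the scatter). The range of groups at this place now extends from two aryl groups to benzyl, a group with a carbon count of its own and no chlorine or methoxy substituent, yet all three compounds remain within the scatter of one another in this assay, so none of these exchanges has a readable effect on the number. No measured information is available to explain this result.

On these data alone, it remains open whether a longer chain such as 2-phenylethyl, a benzyl group carrying a carboxylic acid, or a saturated amine such as piperidine at this nitrogen would move the number beyond the scatter. As far as these compounds go, it also remains open whether this insensitivity would hold if the 4-methylphenylsulfonyl group elsewhere on the shared core gave way to another group.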